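A few compounds are considered here, and "the series" means these few. Any claim that something is new, unique, unknown or untested is made for them only; others in the source may bear on it.

Compound 1, `Cc1cc(C)cc(NC(=O)COc2cc(C)nc3ccc(Cl)cc23)c1`, in a physicochemical assay for solubility, in phosphate buffer, measured as kinetic solubility, with a stated time of 1 h, at pH 7.4; a lower number here means a less soluble compound, a higher number a more soluble compound: 8000 nM
Compound 2, `CCC(Oc1cc(C)nc2ccc(OC)cc12)C(=O)Nc1cc(C)cc(C)c1`, in this assay: 123000 nM
Compound 3, `COc1ccc2nc(C)cc(OCC(=O)Nc3c(C)cccc3C)c2c1`, in this assay: 112000 nM

Among the three numbers in this assay, compound 3 stands second highest. Its nearest neighbour is compound 2, whose number lies within the scatter of that of compound 3, so the two cannot be told apart. Compound 1 is the furthest away, with a number well below that of compound 3, a gap beyond the scatter.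

Compound 4, `COc1ccc2nc(C)cc(OCC(=O)Nc3noc(C)c3C)c2c1`, is the next compound in the series. It differs from compound 3 in one place: 4,5-dimethyl-1,2-oxazol-3-yl in place of 2,6-dimethylphenyl on an amide-type nitrogen. For the measured compounds named here, no pair of measured compounds differs in that way, so there is no step of this kind to lean on; the shared core and the two-carbon linker of compound 3 are kept unchanged. The step from compound 3 to compound 4 is expected to be small, at most a modest rise, a 1.6-fold higher number from compound 3 to compound 4 (0.21 log units; within the scatter), and could fall within the scatter. For compound 4 in this assay the estimate is 180000 nM, with a range from 70000 nM to 450000 nM.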

Compound 4, solubility: 196000 nM
For compound 4 the middle estimate is 1.1-fold (0.04 log units) below the measured one, within the range that was stated.
By their numbers in this assay, from the lowest: compound 1; then compounds 3, 2 and 4 (each within the scatter of the next).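

For the compounds shown here, on the amide-type nitrogen, 4,5-dimethyl-1,2-oxazol-3-yl in place of 2,6-dimethylphenyl supplies the first single-place step: in this assay the exchange gives a 1.8-fold higher number from compound 3 to compound 4 (0.24 log units; within the scatter) and so does not separate the two compounds. At this position, a five-membered aromatic ring with 2 hetero atoms and 2 hydrogen-bond acceptors can therefore stand in place of a six-membered aromatic ring of carbon only, with no readable difference in this read-out. No measurement shown here bears on why the step has this size.

Going by these compounds, it remains open whether the same exchange would give a comparable step on the core of compound 1 or with the side chain of compound 2. Also open, on these data alone, is how an amine or a carboxylic acid would read in place of these rings on the amide-type nitrogen.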